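Replacing the hydroxyethyl amide of compound 3 with a methoxy(methyl)amino

A few compounds are considered here, and "the series" means these few. Any claim that something is new, unique, unknown or untested is made for them only; others in the source may bear on it.

Of the compounds shown here, three have so far been tested in a functional assay on the whole organism with Rattus norvegicus as the target, at a dose of 20 mg/kg by the oral route; on this read-out lower numbers stand for less inhibition and higher numbers for more inhibition at the one dose given (going by the name of the read-out). Compound 1 `Cc1cccc2c1CC/C2=C\C(=O)NC1CC1` gives 7%, compound 2 `O=C(/C=C1\CCc2cc(Cl)ccc21)NC1CC1` gives 29%, and compound 3 `O=C(/C=C1\CCc2ccc(F)cc21)NCCO` gives 78%. Compound 3 stands highest of the three numbers: its nearest neighbour is compound 2, whose value lies beyond the scatter below it, and compound 1 lies further still.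

Compound 4 `CON(C)C(=O)/C=C1\CCc2ccc(F)cc21` has not been measured in this assay. It differs from compound 3 in one place: methoxy(methyl)amino in place of (2-hydroxyethyl)amino on a carbonyl carbon. For the measured compounds named here, no pair of measured compounds differs by such a swap, so the size of this step cannot be read from any measured step. Because compound 3 already gives 78%, the room upward is small, and a downward step beyond the scatter is expected, with wide uncertainty. Compound 4 is therefore estimated to give 45%, ranging from 15% to 75%, which would mean an expected step of a number 33 percentage points lower from compound 3 to compound 4 (beyond the scatter).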

Compound 4, a percentage reported as inhibition, in the whole organism at one dose (the size of the read-out at that dose, not a potency): 14%
Compound 4: the middle estimate sits 31 percentage points above what was measured, and the stated range ends above it.
By their numbers in this assay, from the lowest: compounds 1 and 4 (each within the scatter of the next); then compound 2; then compound 3.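

In this assay, for the compounds shown here, the change on the carbonyl carbon gives the first step in this set that can be read at a single place, a number 64 percentage points lower from compound 3 to compound 4 (beyond the scatter), so the read-out depends strongly on the group at this position. The two groups match in heavy atoms, and the computed counts separate them by hydrogen-bond donors: (2-hydroxyethyl)amino has 2, and methoxy(methyl)amino has 0. This difference is only a count, and nothing available here bears on the cause of the step.

The compounds shown leave open whether the hydroxyl or the amide hydrogen matters more to the read-out, as a plain methylamino or a 2-methoxyethylamino group on the same carbonyl carbon could help to separate. From the compounds shown here alone, how a longer chain, such as 3-hydroxypropylamino, or an amine at the end of the chain would read at this position also remains open.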